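Working notes: benzyl variation on the shared core

A few compounds are considered here, and "the series" means these few. Any claim that something is new, unique, unknown or untested is made for them only; others in the source may bear on it.

Compound 1 `O=C(O)c1ccccc1-c1ccc(CCc2ncc(C3CCCCC3)[nH]2)cc1` and compound 2 `O=C(O)c1ccccc1-c1ccc(CCc2ncc(Cc3ccccc3Cl)[nH]2)cc1` share one core and differ in a single place, the group on an aromatic carbon. In an in vitro functional assay on cells for agonist activity at Bombesin receptor subtype-3 (Homo sapiens), read by luminescence and calcium flux (a lower number here means that less compound is needed, a higher number that more compound is needed for the effect), compound 1 gives 375 nM; in the same assay compound 2 gives 292 nM. Among the compounds with values here, the step of a 1.3-fold lower number from compound 1 to compound 2 (0.11 log units; within the scatter) is within the scatter, so the two cannot be ordered; compound 2 simply holds the lowest of the two numbers so far.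

Compound 3 `N#Cc1cccc(Cc2cnc(CCc3ccc(-c4ccccc4C(=O)O)cc3)[nH]2)c1` follows from compound 2 by 3-cyanophenyl in place of 2-chlorophenyl on a saturated chain carbon bound to an aromatic carbon. Within the data shown here, only one measured step bears on this region, a 1.3-fold lower number from compound 1 to compound 2 (0.11 log units; within the scatter), and it stayed within the scatter although it exchanged the whole group. Nothing measured separates a chlorine substituent from a nitrile on the benzyl ring. The expectation for compound 3 in this assay is therefore a step of a 1.0-fold higher number from compound 2 to compound 3 (0.01 log units; within the scatter), none beyond the scatter. Compound 3 is estimated at 300 nM, with a range from 100 nM to 900 nM.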

Compound 3, half-maximal effective concentration: 812 nM
Compound 3: the middle estimate sits 2.7-fold (0.43 log units) below what was measured; measured number inside the range.
By their numbers in this assay, from the lowest: compounds 2 and 1 (each within the scatter of the next); then compound 3.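

The group on this aromatic carbon can shift the number in this assay, which the step from cyclohexyl to 2-chlorobenzyl could not show. Exchanging 2-chlorobenzyl for 3-cyanobenzyl moves it beyond the scatter (a 2.8-fold higher number from compound 2 to compound 3 (0.44 log units; beyond the scatter)), and 3-cyanobenzyl in place of cyclohexyl does the same (a 2.2-fold higher number from compound 1 to compound 3 (0.34 log units; beyond the scatter)), so among these three groups 3-cyanobenzyl alone stands apart, though both steps are modest. No available evidence accounts for this shift.

The change replaces chlorine with a nitrile and also alters the substitution on the ring, so the contribution of each remains unresolved. Also open, as far as these compounds go, is how a plain benzyl group, or a benzyl ring carrying an amine, would stand against these three groups on the shared core.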